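Cyclobutyl to 4-fluorobenzyl at the chain carbon of compound 1

A few compounds are considered here, and "the series" means these few. Any claim that something is new, unique, unknown or untested is made for them only; others in the source may bear on it.

Compound 1 `O=C(O)c1ccccc1-c1ccc(CCc2ncc(CC3CCC3)[nH]2)cc1` gives 7.1 nM in an in vitro functional assay on cells for agonist activity at Bombesin receptor subtype-3 (Mus musculus), read by luminescence and calcium flux (a higher number here means that more compound is needed for the effect, a lower number that less compound is needed), the lowest of the three numbers recorded. Compound 2 `O=C(O)c1ccccc1-c1ccc(CCc2ncc(Cc3cccc(F)c3)[nH]2)cc1` gives 7.9 nM, and compound 3 `COc1cccc(Cc2cnc(CCc3ccc(-c4ccccc4C(=O)O)cc3)[nH]2)c1` gives 79 nM. The step of a 1.1-fold higher number from compound 1 to compound 2 (0.05 log units; within the scatter); the step of an 11-fold higher number from compound 1 to compound 3 (1.05 log units; beyond the scatter); and the step of a 10-fold higher number from compound 2 to compound 3 (1.00 log units; beyond the scatter).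

Compound 4 `O=C(O)c1ccccc1-c1ccc(CCc2ncc(Cc3ccc(F)cc3)[nH]2)cc1` is not yet measured. It differs from compound 1 as follows: 4-fluorophenyl in place of cyclobutyl on a saturated chain carbon bound to an aromatic carbon. Within the data shown here, the step of a 1.1-fold higher number from compound 1 to compound 2 (0.05 log units; within the scatter) is the closest guide, since both replace cyclobutyl with a fluorophenyl group; no measured pair separates 3-fluorophenyl from 4-fluorophenyl, so that part is unknown. The expected step is therefore a 1.4-fold higher number from compound 1 to compound 4 (0.15 log units; within the scatter), a small change expected in either direction. Compound 4 is estimated at 10 nM, with a range of 3 nM to 35 nM.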

Compound 4, half-maximal effective concentration: 50 nM
Estimate against measurement, compound 4: 5.0-fold (0.70 log units) below, and the stated range ends below it.
By their numbers in this assay, from the lowest: compounds 1 and 2 (each within the scatter of the next); then compounds 4 and 3 (each within the scatter of the next).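

In this assay 4-fluorophenyl in place of 3-fluorophenyl on this saturated chain carbon gives a 6.3-fold higher number from compound 2 to compound 4 (0.80 log units; beyond the scatter) and so the place of the fluorine on the ring counts here, which compounds 1 and 2 alone did not show. Set against cyclobutyl, the same group gives a 7.0-fold higher number from compound 1 to compound 4 (0.85 log units; beyond the scatter) even though 3-fluorophenyl stayed within the scatter of cyclobutyl. Against 3-methoxyphenyl it gives a 1.6-fold lower number from compound 3 to compound 4 (0.20 log units; within the scatter) so compounds 3 and 4 sit together, apart from compounds 1 and 2.

On these data alone, whether an unsubstituted phenyl or a 4-chlorophenyl on this chain carbon would fall with compounds 1 and 2 remains open. No evidence at hand accounts for the gap between the two fluorophenyl compounds.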